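The source may report more compounds than this note shows. Statements on the series, on what has been measured and on what is new or still open speak of the compounds shown alone.

Measured in a functional assay on HepG2 cells (Homo sapiens) for antiproliferative activity, read by MTT assay, with a stated time of 96 h; a higher number here means a weaker inhibitor of growth, a lower number a stronger inhibitor of growth:
- compound 1 `O=C(CCNC(=O)c1cc(-c2ccc(F)cc2)[nH]n1)NO`: 76000 nM
- compound 2 `O=C(NO)c1ccc(CNC(=O)c2cc(-c3ccc(F)cc3)[nH]n2)cc1`: 38100 nM

Compound 1, at 76000 nM, and compound 2, at 38100 nM, lie within the usual scatter of each other, so these numbers do not separate them. Compound 3 `O=C(CCCCCNC(=O)c1cc(-c2ccc(F)cc2)[nH]n1)NO` has not yet been measured. It keeps the core of compound 1 and differs in its chain: 3-(hydroxycarbamoyl)propyl in place of hydroxycarbamoyl on a saturated chain carbon, two bonds along the chain from an amide-type nitrogen. In words, 3-(hydroxycarbamoyl)propyl stands in place of hydroxycarbamoyl on a saturated chain carbon, two bonds along the chain from an amide-type nitrogen. Going by the values given here, no measured step shows what such a change does in this assay, so the expectation rests on the structural change alone and remains uncertain. A moderate move toward stronger inhibition of growth is expected, estimated as a 5.1-fold lower number from compound 1 to compound 3 (0.70 log units; beyond the scatter). For compound 3 the estimated value is 15000 nM, with an expected range of 3000 nM to 60000 nM.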

Compound 3, concentration for 50% growth inhibition: 47600 nM
The estimate for compound 3 lay 3.2-fold (0.50 log units) below the measured number; low and high end bracket the measured number.
By their numbers in this assay, from the lowest: compounds 2, 3 and 1 (each within the scatter of the next).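

In this assay, putting 3-(hydroxycarbamoyl)propyl in place of hydroxycarbamoyl on a saturated chain carbon, two bonds along the chain from an amide-type nitrogen, gives a 1.6-fold lower number from compound 1 to compound 3 (0.20 log units; within the scatter), so this extension does not separate the two compounds. Going by these compounds alone, it is the first step that can be read at this position, and it shows that this added chain length leaves the number within the scatter. No measurement at hand bears on why the number responds in this way.

The compounds shown leave open whether a longer chain than this one, or a carboxylic acid or an amine in place of the hydroxycarbamoyl end, would move the number beyond the scatter. They also leave open what a chlorine in place of the fluorine on the shared core would do.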